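Swapping Carboxy for Hydroxymethyl on the Fused Core

A few compounds are considered here, and "the series" means these few. Any claim that something is new, unique, unknown or untested is made for them only; others in the source may bear on it.

Of the compounds shown here, two have been measured in a functional assay (aorta) with Oryctolagus cuniculus as the target; a lower number here means tighter binding, a higher number weaker binding. Compound 1 `CCCc1nc2c(C)ccnc2n1Cc1cc(Cl)c(O)c(Cl)c1` gives 1.26 nM, while compound 2 `O=C(O)c1ccccc1-c1ccc(Cn2c(C3CC3)nc3c(C(=O)O)ccnc32)cc1` gives 25.1 nM, the higher of the two numbers and beyond the usual scatter from compound 1. Compound 3 `O=C(O)c1ccccc1-c1ccc(Cn2c(C3CC3)nc3c(CO)ccnc32)cc1` differs from compound 2 in one place: hydroxymethyl in place of carboxy on an aromatic carbon. Within the data shown here, no measured pair shows what this change does, so the expectation rests on the change alone. A small step is expected, a 1.6-fold higher number from compound 2 to compound 3 (0.20 log units; within the scatter), perhaps toward a slightly higher number. Compound 3 is therefore estimated at 40 nM in this assay, within 8 nM to 200 nM.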

Compound 3, dissociation constant: 10 nM
The estimate for compound 3 lay 4.0-fold (0.60 log units) above the measured number; the range from low to high includes it.
By their numbers in this assay, from the lowest: compound 1; then compound 3; then compound 2.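

In this assay, hydroxymethyl in place of carboxy on this aromatic carbon, opposite the ring nitrogen, gives a 2.5-fold lower number from compound 2 to compound 3 (0.40 log units; beyond the scatter). This only measured pair at the position shows that the carboxy group can be replaced without the number rising, and that a group with one carbon and one oxygen is tolerated here. Nothing given here explains the step.

Still open, as far as these compounds go, is what an amine, an amide or a longer chain such as hydroxyethyl would do on this same carbon. From the compounds shown here alone, whether the step would hold on other cores also remains unknown.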